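The source may report more compounds than this note shows. Statements on the series, on what has been measured and on what is new or still open speak of the compounds shown alone.

Measured so far: compound 1 `COc1cc2c(=O)c(C(=O)c3ccc(C)cc3)cn(Cc3ccc(Cl)cc3)c2cc1OC`, compound 2 `COc1cc2c(=O)c(S(=O)(=O)CCc3ccc(Cl)cc3)cn(Cc3ccccc3)c2cc1OC`, compound 3 `CCOC(=O)c1cn(Cc2ccc(Cl)cc2)c2cc(OC)c(OC)cc2c1=O`.

In an ADME assay on Huh-7 cells (Homo sapiens) for cytotoxicity (a lower number here means a stronger inhibitor of growth, a higher number a weaker inhibitor of growth), compound 1 gives 15500 nM. Compound 2 is reported in this assay as "not active" (no number reported). For compound 3 the entry of > 15000 nM in this assay is a limit of the assay, not a number. Within the data shown here, compound 1 thus holds the only number among the three. The step that the limit leaves unreadable from compound 1 to compound 3, ethoxy in place of 4-methylphenyl on a carbonyl carbon, cannot be read because of the limit of > 15000 nM in this assay, at which 1 of the 3 values shown sits. Compound 4 `COc1cc2c(=O)c(C(=O)c3ccc(C)cc3)cn(Cc3ccc(N)cc3)c2cc1OC` differs from compound 1 by amino in place of chloro on an aromatic carbon. Among the measured compounds shown here, no measured step touches that ring, so no shift beyond the scatter is expected, and compound 4 may itself return only a limit. Compound 4 is estimated at 15000 nM, between 6000 nM and 40000 nM, an expected step of a 1.0-fold lower number from compound 1 to compound 4 (0.01 log units; within the scatter) within the scatter.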

Compound 4, concentration for 50% growth inhibition: "not active" (no number reported)
For compound 4 the study gives words and no number; the estimate stays without a comparison.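

Among these compounds, compound 4 is reported in words only, so no step from compound 1 to compound 4 can be read in this assay. The compounds shown leave open what amino in place of chloro does to growth inhibition in numbers.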